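Sulfonyl substituent and solubility in the urea series

This account rests on a few compounds, and the source may have more. Where it says the series, first, only, none or still open, it means among the compounds named here.

Compound 1 `O=C(NCc1ccc(S(=O)(=O)c2cncc(C(F)(F)F)c2)cc1)N1Cc2ccncc2C1` is the anchor of this comparison. Among the compounds with values here, in a physicochemical assay for solubility, in phosphate buffer, with a stated time of 24 h, at pH 7.4, tested at 100 uM (on this read-out higher numbers stand for higher solubility and lower numbers for lower solubility), compound 1 gives 83000 nM, the lowest of the three numbers so far. Compound 2 `CCCn1cc(S(=O)(=O)c2ccc(CNC(=O)N3Cc4ccncc4C3)cc2)cn1` gives 105000 nM in this assay, and compound 3 `CN1CCC(S(=O)(=O)c2ccc(CNC(=O)N3Cc4ccncc4C3)cc2)CC1` gives 240000 nM. The step of a 1.3-fold higher number from compound 1 to compound 2 (0.10 log units; within the scatter) stays within the scatter, whereas a 2.9-fold higher number from compound 1 to compound 3 (0.46 log units; beyond the scatter) and a 2.3-fold higher number from compound 2 to compound 3 (0.36 log units; beyond the scatter) are modest but real.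

Compound 4 `O=C(NCc1ccc(S(=O)(=O)N2CC3(CCOCC3)C2)cc1)N1Cc2ccncc2C1` is unmeasured. It differs from compound 1 in one place: a group of 9 heavy atoms (7 carbon, 1 nitrogen, 1 oxygen; one four-membered non-aromatic ring with 1 hetero atom, one six-membered non-aromatic ring with 1 hetero atom) in place of a group of 10 heavy atoms (6 carbon, 1 nitrogen, 3 fluorine; one six-membered aromatic ring with 1 hetero atom), on a sulfonyl sulfur. Both measured steps from compound 1 exchange the same group on the sulfonyl sulfur, so both bear on this change; the closer parallel is compound 3, where 1-methylpiperidin-4-yl also brought a non-aromatic ring onto the sulfonyl sulfur, and that comparison is weighted more because a 2.9-fold higher number from compound 1 to compound 3 (0.46 log units; beyond the scatter) was the larger of the two. A modest rise beyond the scatter is therefore expected in this assay, but not a large one. For compound 4 the expected step is a 2.2-fold higher number from compound 1 to compound 4 (0.34 log units; beyond the scatter). Compound 4 is estimated at 180000 nM in this assay, with a range from 90000 nM to 360000 nM.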

Compound 4, solubility: 272000 nM
Estimate against measurement, compound 4: 1.5-fold (0.18 log units) below; measured number inside the range.
By their numbers in this assay, from the lowest: compounds 1 and 2 (each within the scatter of the next); then compounds 3 and 4 (each within the scatter of the next).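

Compound 4 gives a second non-aromatic replacement on the sulfonyl sulfur in this assay, with a 3.3-fold higher number from compound 1 to compound 4 (0.52 log units; beyond the scatter) and a 2.6-fold higher number from compound 2 to compound 4 (0.41 log units; beyond the scatter) as its steps from the two aromatic-ring groups. Against 1-methylpiperidin-4-yl, a 1.1-fold higher number from compound 3 to compound 4 (0.05 log units; within the scatter) leaves the two non-aromatic groups indistinguishable, and across these four compounds both stand beyond the scatter from both aromatic-ring groups, with no compound against that split. Nothing on hand accounts for this split.

Open, as far as these compounds go, is whether the split holds for a non-aromatic ring group carrying a carboxylic acid, or for an open-chain group such as a dialkylamine on the sulfonyl sulfur. Also open, from the compounds shown here alone, is whether a phenyl group on the sulfonyl sulfur would sit with compound 1 and compound 2.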